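This account rests on a few compounds, and the source may have more. Where it says the series, first, only, none or still open, it means among the compounds named here.

Three members of the series are measured. Compound 1 `CN(C)CCCNc1nc(-c2ccc(NC(=O)Nc3ccc(Cl)cc3)cc2)nc2c(Cl)c(Cl)sc12` gives 1530 nM in a functional assay on MKN-45 cells (Homo sapiens) for cytotoxicity, read by MTT assay, with a stated time of 72 h; a lower number here means a stronger inhibitor, a higher number a weaker inhibitor. Compound 2 `CN(C)CCCNc1nc(-c2ccc(NC(=O)Nc3ccc(Cl)cc3Cl)cc2)nc2c(Cl)c(Cl)sc12` gives 2560 nM in this assay. Compound 3 `CN(C)CCNc1nc(-c2ccc(NC(=O)Nc3ccccc3Cl)cc2)nc2ccsc12` gives 850 nM in this assay; its number and that of compound 1 lie within the scatter of each other, while compound 2 stands beyond the scatter from compound 3. Compound 1 and compound 2 differ in one place, (chloro in place of hydrogen on an aromatic carbon), and the step is a 1.7-fold higher number from compound 1 to compound 2 (0.22 log units; within the scatter). Compound 4 `CN(C)CCNc1nc(-c2ccc(NC(=O)Nc3ccc(Cl)cc3Cl)cc2)nc2ccsc12` is not yet measured; it differs from compound 3 by chloro in place of hydrogen on an aromatic carbon. The difference between the core of compound 3 and the core of compound 1 is not broken down here. The two changes are the same kind of change but not the same: in the first the entering chloro sits ortho to a large group and meta to a chloro group, in the second meta to a chloro group and para to a large group. For compound 4 the expected step in this assay is a 1.5-fold higher number from compound 3 to compound 4 (0.18 log units; within the scatter), resting on a 1.7-fold higher number from compound 1 to compound 2 (0.22 log units; within the scatter), which lies within the scatter. On that basis compound 4 is estimated at 1300 nM, with 600 nM to 2800 nM as the expected range.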

Compound 4, half-maximal inhibitory concentration: 2360 nM
Compound 4: middle estimate off by 1.8-fold (0.26 log units), on the low side, within the range that was stated.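

In this assay, the change from 2-chlorophenyl to 2,4-dichlorophenyl gives a 2.8-fold higher number from compound 3 to compound 4 (0.44 log units; beyond the scatter). Set beside the same kind of change on the core of compound 1, the two steps cannot be told apart: the same change on two cores in this assay, a 1.7-fold higher number (0.22 log units; within the scatter) from compound 1 to compound 2 and a 2.8-fold higher number (0.44 log units; beyond the scatter) from compound 3 to compound 4, 1.7-fold (0.22 log units) apart, within the scatter of two such steps

Among these compounds, the chloro can therefore be carried between these two cores without a detectable difference in its step, but this rests on one pair per core, the entering chloro does not stand at the same place in the two pairs, and only the step on the shared core of compound 3 and compound 4 lies beyond the scatter, so no general rule for the series follows.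

Still open, from the compounds shown here alone, is whether fluoro, methoxy or trifluoromethyl in the place of this chloro would give a step of similar size on both cores. The compounds shown also leave open how the step behaves when a morpholine or a piperazine replaces the dimethylamino group at the end of the chain.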